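A few compounds are considered here, and "the series" means these few. Any claim that something is new, unique, unknown or untested is made for them only; others in the source may bear on it.

Of the compounds shown here, three built on a shared core have been measured in a functional assay on T47D cells (Homo sapiens) for inhibition, read by sulforhodamine B assay, with a stated time of 48 h; on this read-out higher numbers stand for weaker inhibition of growth and lower numbers for stronger inhibition of growth. Compound 1 `COC(=O)[C@@]1(C)CCC=C2[C@@H]1CC[C@@H](C)[C@]2(C)Cc1c[nH]c2ccccc12` gives 4200 nM. Compound 2 `COC(=O)[C@@]1(C)CCC=C2[C@@H]1CC[C@@H](C)[C@]2(C)Cc1c(C)[nH]c2ccccc12`, which carries a methyl on the five-membered aromatic ring, gives 17000 nM, the highest of the three numbers. Compound 3 `COC(=O)[C@@]1(C)CCC=C2[C@@H]1CC[C@@H](C)[C@]2(C)Cc1c(C)[nH]c2ccc(Br)cc12` gives 16000 nM, which lies within the usual scatter of compound 2, so the two cannot be told apart. The step of a 4.0-fold higher number from compound 1 to compound 2 (0.61 log units; beyond the scatter) is a modest loss that lies beyond the scatter, while the step of a 1.1-fold lower number from compound 2 to compound 3 (0.03 log units; within the scatter) is within it.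

Compound 4 `COC(=O)[C@@]1(C)CCC=C2[C@@H]1CC[C@@H](C)[C@]2(C)Cc1c(C=O)[nH]c2ccccc12` has not yet been measured. It differs from compound 2 in one place: formyl in place of methyl on an aromatic carbon. Within the data shown here, no measured step involves a formyl group, so nothing here shows directly what this exchange does. Among the measured compounds shown here, the only measured step at this place, a 4.0-fold higher number from compound 1 to compound 2 (0.61 log units; beyond the scatter), shows that placing a methyl there raised the number. Replacing that methyl with a formyl could undo part of that, or leave the number where it is, as the step of a 1.1-fold lower number from compound 2 to compound 3 (0.03 log units; within the scatter) shows that a change on the aromatic rings need not move the number at all. The expected step is therefore a 1.7-fold lower number from compound 2 to compound 4 (0.23 log units; within the scatter), small and uncertain in direction. Compound 4 is expected to give about 10000 nM in this assay, between 3000 nM and 35000 nM.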

Compound 4, concentration for 50% growth inhibition: 17000 nM
Estimate against measurement, compound 4: 1.7-fold (0.23 log units) below, and the stated range covers the measured number.
By their numbers in this assay, from the lowest: compound 1; then compounds 3, 2 and 4 (each within the scatter of the next).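

Exchanging the methyl for a formyl on this carbon of the five-membered aromatic ring leaves growth inhibition in this assay unchanged (no change at the digits printed from compound 2 to compound 4 (within the scatter)), even though the formyl adds a heavy atom and a hydrogen-bond acceptor. Measured against hydrogen at the same carbon, the formyl gives a modest loss (a 4.0-fold higher number from compound 1 to compound 4 (0.61 log units; beyond the scatter)), so the loss first seen with compound 2 is not limited to a methyl: for these two groups, compounds 2 and 4 cannot be told apart, and compound 1, with hydrogen here, has the lower number. Nothing available explains why the two groups give the same result.

The compounds shown leave open whether other groups on this carbon, such as an amine, a carboxylic acid or a longer chain, would stay level with compounds 2 and 4, return to the number of compound 1, or move the number further. They also leave open whether any group here can give a lower number than hydrogen does, and whether a bromo on the six-membered ring would again make no difference alongside a formyl.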